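Dopamine Transporter Binding of Arylpiperazine Naphthamides and Quinolinecarboxamides

The source may hold more compounds than are shown below. What is called first, only, known or untested is meant among the compounds shown, and "the series" means these compounds.

Compound 1 `O=C(NCCCN1CCN(c2ncccn2)CC1)c1ccc2ccccc2c1`: > 10000 nM
Compound 2 `O=C(NCCCN1CCN(c2cccc(Cl)c2Cl)CC1)c1ccc2ccccc2c1`: > 10000 nM
Compound 3 `O=C(NCCCN1CCN(c2ncccn2)CC1)c1ccc2ccccc2n1`: > 10000 nM

In an assay on HEK293 cells for inhibition of sodium-dependent dopamine transporter (Homo sapiens), read by scintillation counting (on this read-out lower numbers stand for stronger inhibition and higher numbers for weaker inhibition), compound 1 gives only a limit, > 10000 nM. Compound 2 also gives a limit in this assay, > 10000 nM. Compound 3 gives a limit as well, > 10000 nM. The change 2,3-dichlorophenyl in place of pyrimidin-2-yl on an amine nitrogen in a ring therefore yields a step that the two limits leave unreadable from compound 1 to compound 2. The difference between the core of compound 1 and the core of compound 3 is not broken down here.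

Compound 4 `O=C(NCCCN1CCN(c2cccc(Cl)c2Cl)CC1)c1ccc2ccccc2n1` has not been measured. It carries the same change on the core of compound 3, (2,3-dichlorophenyl in place of pyrimidin-2-yl on an amine nitrogen in a ring). Because (the limit of > 10000 nM in this assay, at which 3 of the 3 values shown sit), compound 4 is expected to stay at that limit, and the expected step is a step that the limit leaves unreadable from compound 3 to compound 4. The estimate for compound 4 is 15000 nM, expected to lie between 5000 nM and 50000 nM.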

Compound 4, half-maximal inhibitory concentration: > 10000 nM
Compound 4: a limit, no number; the forecaster's own chance of this, stated with the estimate: 85%; the middle value does not contradict the limit.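

Compound 4 gives only a limit, > 10000 nM, and the steps to it from compound 2 and compound 3 cannot be read. The compounds shown leave open whether either change alters inhibition in this assay at all.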